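Trimming the side chain of compound 2

A few compounds are considered here, and "the series" means these few. Any claim that something is new, unique, unknown or untested is made for them only; others in the source may bear on it.

Going by the values given here, in a functional assay on SW1573 cells (Homo sapiens) for antiproliferative activity, read by sulforhodamine B assay, with a stated time of 48 h (on this read-out lower numbers stand for stronger inhibition of growth and higher numbers for weaker inhibition of growth), compound 2 `COC(=O)C#CC(CC(C)C)O/C=C/C(=O)OC` gives 380 nM as the lower of the two numbers so far, while compound 1 `COC(=O)C#CC(O/C=C/C(=O)OC)C1CCCCC1` gives 2100 nM on the same read-out. Compound 3 `COC(=O)C#CC(C)O/C=C/C(=O)OC` differs from compound 2 by hydrogen in place of isopropyl on a saturated chain carbon, two bonds along the chain from an oxygen on an unsaturated carbon and a triple-bonded carbon so that isobutyl becomes methyl. Among the compounds with values here, the only measured step bearing on this is a 5.5-fold lower number from compound 1 to compound 2 (0.74 log units; beyond the scatter) for isobutyl in place of cyclohexyl, and a single step sets no trend. The expected move is a 1.3-fold lower number from compound 2 to compound 3 (0.10 log units; within the scatter) and so smaller than that modest step. Compound 3 is estimated at 300 nM and is expected to fall from 70 nM to 1300 nM on repeated measurement.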

Compound 3, concentration for 50% growth inhibition: 1700 nM
Estimate against measurement, compound 3: 5.7-fold (0.75 log units) below; measured number above the stated range.
By their numbers in this assay, from the lowest: compound 2; then compounds 3 and 1 (each within the scatter of the next).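

Taking the side chain from isobutyl down to methyl gives a 4.5-fold higher number from compound 2 to compound 3 (0.65 log units; beyond the scatter), so removing carbons at this position does not keep lowering the number, as the change from cyclohexyl to isobutyl might have suggested. Methyl and cyclohexyl, very different groups, end up level, with a 1.2-fold lower number from compound 1 to compound 3 (0.09 log units; within the scatter), which leaves isobutyl alone with the lowest number of the three. Nothing given here explains this pattern.

Three groups cannot show how narrow this preference is. An ethyl group, a longer chain or a chain ending in an amine could land on either side of compound 2.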